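The source may report more compounds than this note shows. Statements on the series, on what has been measured and on what is new or still open speak of the compounds shown alone.

Measured compounds in this series:

compound 1 `Cn1cnc2nncc-2c1S`: 13%
compound 2 `CCCn1cnc2ncnn2c1=S`: 49%
compound 3 `Cn1cnc2nc(-c3ccccc3)nn2c1=S`: 1%

All three were run in a functional assay on the whole organism for inhibition, with Rattus norvegicus as the target, at a dose of 30 mg/kg by the intraperitoneal route; on this read-out higher numbers stand for more inhibition at the one dose given (going by the name of the read-out) and lower numbers for less inhibition. Compound 3 stands lowest of the three numbers in this assay. Its nearest neighbour is compound 1, which lies higher by a margin beyond the scatter; compound 2 lies higher still, also beyond the scatter. No two of the measured compounds differ in only one place, so no single-point step can be read from the numbers.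

The next compound, compound 4 `Cn1cnc2nc(-c3ccc(Cl)cc3)nn2c1=S`, differs from compound 3 by one change: chloro in place of hydrogen on an aromatic carbon. Going by the values given here, none of the measured pairs shows this kind of change, so the numbers give no direct guide to its effect. Given the small size of the change and the low starting point of compound 3, the step from compound 3 to compound 4 in this assay is expected to be small, if anything slightly upward, and likely within the scatter: a number 7 percentage points higher from compound 3 to compound 4 (within the scatter). Compound 4 is therefore estimated at 8% in this assay, with a range from 0% to 25%.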

Compound 4, a percentage reported as inhibition, in the whole organism at one dose (the size of the read-out at that dose, not a potency): 92%
For compound 4 the middle estimate is 84 percentage points below the measured one; measured number outside the range, above it.
By their numbers in this assay, from the lowest: compound 3; then compound 1; then compound 2; then compound 4.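

Chloro in place of hydrogen on an aromatic carbon of the six-membered aromatic ring, para to a large group, gives a number 91 percentage points higher from compound 3 to compound 4 (beyond the scatter) in this assay. Going by these compounds alone, this is the first single-change comparison, and it shows that the read-out is highly sensitive to this position: one heavy atom, with no hydrogen-bond donors or acceptors and no net charge, is enough to produce a large step. Nothing available explains why this one change has so large an effect.

As far as these compounds go, it remains open whether the step is specific to chloro or would also appear with fluoro, methyl, methoxy or an amine at this position, or with chloro on another carbon of the ring. The step rests on a single pair at one dose, so no wider trend can be drawn from it.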